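A few compounds are considered here, and "the series" means these few. Any claim that something is new, unique, unknown or untested is made for them only; others in the source may bear on it.

Measured compounds in this series:
compound 1, `C/C=C/C(=O)Nc1cccc(Oc2nc(Nc3ccn(C)n3)nc3c2CSCC3)c1`, in an ADME assay on L02 cells (Homo sapiens) for cytotoxicity, read by MTT assay, with a stated time of 72 h (a lower number here means a stronger inhibitor, a higher number a weaker inhibitor), gives > 50000 nM, which is a limit of the assay.
compound 2, `CC/C=C/C(=O)Nc1cccc(Oc2nc(Nc3ccn(C)n3)nc3c2CSCC3)c1`, in this assay gives > 50000 nM, likewise a limit.
compound 3, `CC/C=C/C(=O)Nc1cccc(Oc2nc(Nc3ccc(OC)cc3)nc3c2CSCC3)c1`, in this assay gives > 50000 nM, likewise a limit.

From compound 1 to compound 2 the change is methyl in place of hydrogen on a saturated chain carbon bound to a double-bonded chain carbon; the step that the two limits leave unreadable from compound 1 to compound 2. From compound 2 to compound 3 the step that the two limits leave unreadable from compound 2 to compound 3. The difference between the core of compound 1 and the core of compound 3 is not broken down here.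

Compound 4, `CCC/C=C/C(=O)Nc1cccc(Oc2nc(Nc3ccc(OC)cc3)nc3c2CSCC3)c1`, is not yet measured. It differs from compound 3 by methyl in place of hydrogen on a saturated chain carbon, two bonds along the chain from a double-bonded chain carbon. This is the same kind of change as from compound 1 to compound 2, but the place is not the same: there the methyl enters on a saturated chain carbon bound to a double-bonded chain carbon, here on a saturated chain carbon two bonds along the chain from a double-bonded chain carbon.

In this assay the step that the limit leaves unreadable from compound 3 to compound 4 is expected beside a step that the two limits leave unreadable from compound 1 to compound 2 to stay unreadable as well, because the limit of > 50000 nM in this assay, at which 3 of the 3 values shown sit, holds all three measured compounds. Compound 4 is therefore estimated at 70000 nM, with a range of 30000 nM to 250000 nM, most likely again reported only as a limit.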

Compound 4, half-maximal inhibitory concentration: > 50000 nM
Compound 4: only a limit was reported; the forecaster's own chance of this, stated with the estimate: 85%; the middle value does not contradict the limit.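

In this assay, among the compounds shown here, compound 4 gives > 50000 nM, a limit of the assay, and with compound 3 also reported only as a limit, no step between compound 3 and compound 4 can be read. The compounds shown leave open how far any of them lies beyond that limit, and whether lengthening the chain changes cytotoxicity at all.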